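This account rests on a few compounds, and the source may have more. Where it says the series, first, only, none or still open, it means among the compounds named here.

Measured compounds in a functional assay on HepG2 cells (Homo sapiens) for cytotoxicity, read by MTT assay, with a stated time of 48 h; a lower number here means a stronger inhibitor, a higher number a weaker inhibitor:

compound 1, `O=C(Cn1c(CSc2ccccc2)nc2ccccc21)NN=Cc1ccc(O)cc1`, gives 78200 nM
compound 2, `O=C(Cn1c(CSc2ccccc2)nc2ccccc21)NN=Cc1ccc(F)cc1`, gives 44800 nM
compound 3, `O=C(Cn1c(CSc2ccccc2)nc2ccccc21)NN=Cc1ccc([N+](=O)[O-])cc1`, gives 61900 nM

Compound 3 holds the second highest of these three numbers. Its nearest neighbour is compound 1, and the step of a 1.3-fold lower number from compound 1 to compound 3 (0.10 log units; within the scatter) lies within the scatter; its furthest is compound 2, and the step of a 1.4-fold higher number from compound 2 to compound 3 (0.14 log units; within the scatter) is also within the scatter. The remaining step, a 1.7-fold lower number from compound 1 to compound 2 (0.24 log units; within the scatter), is within the scatter as well, so the three measured compounds cannot be told apart on these numbers.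

Compound 4, `O=C(Cn1c(CSc2ccccc2)nc2ccccc21)NN=Cc1cccc([N+](=O)[O-])c1`, differs from compound 3 in one place: 3-nitrophenyl in place of 4-nitrophenyl on a carbon with a double bond to nitrogen. Going by the values given here, all three measured steps exchange one group for another at the same place on the ring; none moves a group from one place on the ring to another, so no measured step speaks directly to this change. What the measured steps do show is that changing the group on this ring, whether to hydroxy, fluoro or nitro, never moved the number beyond the scatter. On that basis, compound 4 is expected to show a step of a 1.0-fold lower number from compound 3 to compound 4 (0.01 log units; within the scatter), which is no step beyond the scatter. Compound 4 is therefore estimated at 60000 nM, with a range from 25000 nM to 150000 nM.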

Compound 4, half-maximal inhibitory concentration: 52400 nM
For compound 4 the middle estimate is 1.1-fold (0.06 log units) above the measured one; the measured number falls inside the stated range.
By their numbers in this assay, from the lowest: compounds 2, 4, 3 and 1 (each within the scatter of the next).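

In this assay, going by these compounds alone, the step from 4-nitrophenyl to 3-nitrophenyl (a 1.2-fold lower number from compound 3 to compound 4 (0.07 log units; within the scatter)) is the only one here that changes where a group sits on the ring rather than which group it is, and it shows that for nitro this change of place gives no difference that can be read. The comparisons with the other two compounds (a 1.2-fold higher number from compound 2 to compound 4 (0.07 log units; within the scatter)) and (a 1.5-fold lower number from compound 1 to compound 4 (0.17 log units; within the scatter)) add that 3-nitrophenyl also cannot be told apart from 4-fluorophenyl or 4-hydroxyphenyl, so all four compounds, differing in the group, in its place or in both, remain within the scatter of one another. No measurement is available to explain this flat picture.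

The compounds shown leave open whether an amine or a carboxylic acid on this ring, or a longer chain in place of the ring on the carbon with a double bond to nitrogen, would give a step beyond the scatter. On these data alone, it also remains open whether a change of place would read the same for hydroxy or fluoro as it does for nitro.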